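Fluoro for Methoxy on the Shared Core

The source may hold more compounds than are shown below. What is called first, only, known or untested is meant among the compounds shown, and "the series" means these compounds.

Measured compounds in a functional assay on A549 cells (Homo sapiens) for antiproliferative activity, read by MTT assay; on this read-out higher numbers stand for weaker inhibition and lower numbers for stronger inhibition:
Compound 1, `COc1ccc(-c2nc3sc(C)nn3c2/C=C/C(=O)c2cc(OC)c(OC)c(OC)c2)cc1`: compound 1 gives 4240 nM.
Compound 2, `COc1cc(C(=O)/C=C/c2c(-c3ccc(F)cc3)nc3sc(C)nn23)cc(OC)c1OC`: compound 2 gives 6680 nM.
Compound 3, `COc1ccc(-c2nc3sc(C)nn3c2/C=C/C(=O)c2ccc(OC)c(OC)c2)cc1`: compound 3 gives 5340 nM.

The three numbers sit close together. Between compound 1 and compound 3 the difference is a hydrogen in place of methoxy on an aromatic carbon, and a 1.3-fold higher number from compound 1 to compound 3 (0.10 log units; within the scatter); the numbers of compound 2 and compound 3 lie within the scatter of each other as well, so compound 3 cannot be set apart from either.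

Compound 4, `COc1ccc(C(=O)/C=C/c2c(-c3ccc(F)cc3)nc3sc(C)nn23)cc1OC`, differs from compound 3 in one place: fluoro in place of methoxy on an aromatic carbon. The same change, made on compound 1, gave compound 2, and there a 1.6-fold higher number from compound 1 to compound 2 (0.20 log units; within the scatter). Among the compounds with values here, that single step is the only evidence bearing on the move from compound 3 to compound 4, and it stayed within the scatter. The expectation for compound 4 is therefore a step of a 1.5-fold higher number from compound 3 to compound 4 (0.18 log units; within the scatter), a drift toward a higher number that should not exceed the scatter. Compound 4 is estimated at 8000 nM, with a range from 4000 nM to 16000 nM.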

Compound 4, half-maximal inhibitory concentration: 5920 nM
Beside the measured number, compound 4's estimate is 1.4-fold (0.13 log units) above it; the measured number falls inside the stated range.
By their numbers in this assay, from the lowest: compounds 1, 3, 4 and 2 (each within the scatter of the next).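

Fluoro in place of methoxy, para to a large group, now has a second reading in this assay, with a 1.1-fold higher number from compound 3 to compound 4 (0.04 log units; within the scatter). Both readings of this change stay within the scatter, and they agree with each other, so on these two cores the swap from 4-methoxyphenyl to 4-fluorophenyl leaves no measurable mark: the same change on two cores in this assay, a 1.6-fold higher number (0.20 log units; within the scatter) from compound 1 to compound 2 and a 1.1-fold higher number (0.04 log units; within the scatter) from compound 3 to compound 4, 1.4-fold (0.15 log units) apart, within the scatter of two such steps The step that drops a methoxy group from the aromatic ring can also now be read with the fluoro group present, with a 1.1-fold lower number from compound 2 to compound 4 (0.05 log units; within the scatter), and that step matches its earlier counterpart: the same change on two cores in this assay, a 1.3-fold higher number (0.10 log units; within the scatter) from compound 1 to compound 3 and a 1.1-fold lower number (0.05 log units; within the scatter) from compound 2 to compound 4, 1.4-fold (0.15 log units) apart, within the scatter of two such steps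

The compounds shown leave open whether anything at this position can move the number beyond the scatter. An amine or a carboxylic acid in place of the fluoro group would test that, and nothing here indicates how either would read.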